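A few compounds are considered here, and "the series" means these few. Any claim that something is new, unique, unknown or untested is made for them only; others in the source may bear on it.

Among the compounds with values here, compound 1 `COc1ccc(N(CC(=O)NCCCSc2ccccc2)C(=O)CCSC2=C(C)C(=O)c3ccccc3C2=O)cc1` gives 4.2 in a physicochemical assay for lipophilicity, read by HPLC, measured as octanol-water partition (on this read-out higher numbers stand for higher lipophilicity and lower numbers for lower lipophilicity), the highest of the three numbers so far. Within the data shown here, compound 2 `COc1ccc(N(CC(=O)NCCC[Se]c2ccccc2)C(=O)c2ccccc2)cc1` gives 3.1 in this assay, and compound 3 `COc1ccc(N(CC(=O)NCCC[Se]c2ccccc2)C(=O)CNC(=O)OC(C)(C)C)cc1` gives 3.3; the one measured step, a number 0.20 log units higher from compound 2 to compound 3 (within the scatter), concerns a different part of the molecule. Compound 4 `COc1ccc(N(CC(=O)NCCC[Te]c2ccccc2)C(=O)CCSC2=C(C)C(=O)c3ccccc3C2=O)cc1` differs from compound 1 as follows: a group of 7 heavy atoms (6 carbon, 1 tellurium; one six-membered aromatic ring of carbon only) in place of a group of 7 heavy atoms (6 carbon, 1 sulfur; one six-membered aromatic ring of carbon only), on a saturated chain carbon, three bonds along the chain from an amide-type nitrogen. Among the measured compounds shown here, no measured step covers this change; compounds 2 and 3 carry selenium at the same place, but each also differs from compound 1 elsewhere, so only their values can be noted. The expectation is therefore a small change, a number 0.20 log units higher from compound 1 to compound 4 (within the scatter), not clearly beyond the scatter. Compound 4 is estimated at 4.4, between 4 and 4.8.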

Compound 4, partition coefficient: 1.97
Beside the measured number, compound 4's estimate is 2.43 log units above it, and the stated range ends above it.
By their numbers in this assay, from the lowest: compound 4; then compounds 2 and 3 (each within the scatter of the next); then compound 1.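

In this assay, putting the tellurium group in place of phenylsulfanyl on the saturated chain carbon gives a number 2.23 log units lower from compound 1 to compound 4 (beyond the scatter) and so shows that this position can respond strongly to this exchange. The change is large even though both groups have the same count of heavy atoms and the same aromatic ring. Nothing measured here accounts for the step.

Still open, from the compounds shown here alone, is where the selenium analogue of compound 1 would fall. A phenoxy group at this position, with oxygen in place of sulfur, is also untested among the compounds shown.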